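Fluorine position on the benzyloxy group: thiourea series

This account rests on a few compounds, and the source may have more. Where it says the series, first, only, none or still open, it means among the compounds named here.

compound 1 `Cc1ccc(NC(=S)NC(=O)c2ccc(OCc3ccc(C(F)(F)F)cc3)cc2)cc1-c1nc2ccccc2[nH]1` — 72400 nM in a functional assay on SW-620 cells (Homo sapiens) for inhibition, read by MTT assay, with a stated time of 48 h; on this read-out lower numbers stand for stronger inhibition and higher numbers for weaker inhibition
compound 2 `Cc1ccc(NC(=S)NC(=O)c2ccc(OCc3ccccc3F)cc2)cc1-c1nc2ccccc2[nH]1` — 6440 nM in this assay
compound 3 `Cc1ccc(NC(=S)NC(=O)c2ccc(OCc3cccc(F)c3)cc2)cc1-c1nc2ccccc2[nH]1` — > 100000 nM in this assay, a limit of the assay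

Compound 2 gives the lowest of the two numbers in this assay; the nearest is compound 1, with an 11-fold lower number from compound 1 to compound 2 (1.05 log units; beyond the scatter). Compound 3 stands at the assay floor (the limit of > 100000 nM in this assay, at which 1 of the 3 values shown sits). Compound 4 `Cc1ccc(NC(=S)NC(=O)c2ccc(OCc3ccc(F)cc3)cc2)cc1-c1nc2ccccc2[nH]1` is not yet measured and differs from compound 2 by 4-fluorophenyl in place of 2-fluorophenyl on a saturated chain carbon bound to an oxygen on an aromatic ring. Bearing on this: an at least 15-fold higher number from compound 2 to compound 3 (1.19 log units; beyond the scatter) and an 11-fold lower number from compound 1 to compound 2 (1.05 log units; beyond the scatter), both large, whereas an at least 1.3-fold higher number from compound 1 to compound 3 (0.14 log units; that floor lies within the scatter) lies within the scatter. Among the three measured, only 2-fluorophenyl gives stronger inhibition; 3-fluorophenyl and 4-(trifluoromethyl)phenyl are weak. A large upward step is therefore expected, a 7.8-fold higher number from compound 2 to compound 4 (0.89 log units; beyond the scatter). Compound 4 is estimated at 50000 nM, range 12000 nM to 200000 nM, with a real chance of only a limit.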

Compound 4, half-maximal inhibitory concentration: 40500 nM
Compound 4: the middle estimate sits 1.2-fold (0.09 log units) above what was measured; the measured number falls inside the stated range.
By their numbers in this assay, from the lowest: compound 2; then compounds 4 and 1 (each within the scatter of the next). At a limit, above all of these: compound 3.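

In this assay, 4-fluorophenyl in place of 2-fluorophenyl gives a 6.3-fold higher number from compound 2 to compound 4 (0.80 log units; beyond the scatter), so the low number stays with compound 2 alone among the fluorophenyl groups. In place of 3-fluorophenyl, the same group gives an at least 2.4-fold lower number from compound 3 to compound 4 (0.39 log units; beyond the scatter), a step read from a limit and not from a number: the limit of > 100000 nM in this assay, at which 1 of the 4 values shown sits. Fluoro in place of trifluoromethyl gives a 1.8-fold lower number from compound 1 to compound 4 (0.25 log units; within the scatter), so this swap shows no readable change.

As far as these compounds go, whether the low number needs fluorine itself stays open. A chloro or methoxy group in place of the fluorine of compound 2 would address that.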